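The source may report more compounds than this note shows. Statements on the series, on what has been measured and on what is new or still open speak of the compounds shown alone.

Measured so far:
- compound 1 `Cc1ccc(Nc2ncc(C(F)(F)F)c(N3Cc4cccc(N(C)S(C)(=O)=O)c4C3)n2)cc1C`: > 30000 nM, a limit of the assay
- compound 2 `COc1ccc(C(F)(F)F)cc1Nc1ncc(C(F)(F)F)c(N2Cc3cccc(N(C)S(C)(=O)=O)c3C2)n1`: 17200 nM
- compound 3 `Cc1cc(Cl)ccc1Nc1ncc(C(F)(F)F)c(N2Cc3cccc(N(C)S(C)(=O)=O)c3C2)n1`: 17400 nM

In a functional assay on HeLa cells (Homo sapiens) for antiproliferative activity, read by spectrophotometry, with a stated time of 2 days (on this read-out higher numbers stand for weaker inhibition of growth and lower numbers for stronger inhibition of growth), compound 3 gives 17400 nM, within the scatter of compound 2 . The next step leads to compound 4 `COc1cc(Nc2ncc(C(F)(F)F)c(N3Cc4cccc(N(C)S(C)(=O)=O)c4C3)n2)cc(C(F)(F)F)c1`, with 3-methoxy-5-(trifluoromethyl)phenyl in place of 4-chloro-2-methylphenyl on a nitrogen on an aromatic ring. The closest evidence is the same kind of exchange in a 1.0-fold higher number from compound 2 to compound 3 (0.01 log units; within the scatter). The floors an at least 1.7-fold lower number from compound 1 to compound 2 (0.24 log units; that floor lies within the scatter) and an at least 1.7-fold lower number from compound 1 to compound 3 (0.23 log units; that floor lies within the scatter) also lie within the scatter. No step beyond the scatter is therefore expected in this assay. The expected step is a 1.1-fold higher number from compound 3 to compound 4 (0.06 log units; within the scatter). For compound 4 the estimated value is 20000 nM, with an expected range of 9000 nM to 35000 nM.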

Compound 4, concentration for 50% growth inhibition: 5100 nM
Beside the measured number, compound 4's estimate is 3.9-fold (0.59 log units) above it, and the stated range ends above it.
By their numbers in this assay, from the lowest: compound 4; then compounds 2 and 3 (each within the scatter of the next). At a limit, above all of these: compound 1.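

In this assay, the group on the nitrogen first produces steps beyond the scatter: a 3.4-fold lower number from compound 3 to compound 4 (0.53 log units; beyond the scatter), and a 3.4-fold lower number from compound 2 to compound 4 (0.53 log units; beyond the scatter). The second step keeps methoxy and trifluoromethyl on the ring, so 3-methoxy-5-(trifluoromethyl)phenyl and 2-methoxy-5-(trifluoromethyl)phenyl are not interchangeable here, and the presence of the two groups alone does not set the value. The step of an at least 5.8-fold lower number from compound 1 to compound 4 (0.76 log units; beyond the scatter) is only a floor, and the value of compound 1 is a limit: the limit of > 30000 nM in this assay, at which 1 of the 4 values shown sits.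

From the compounds shown here alone, whether methoxy or trifluoromethyl carries the change remains open. Also open, going by these compounds, is whether an amine or a nitrile in place of the methoxy would keep it.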